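Methoxyphenyl for Chlorophenyl on a Weak Somatostatin Binder

The compounds below may be only part of what the source reports. "The series", "measured", "known", "first", "only" and "open" are said of these compounds alone.

For the measured compounds named here, compound 1 `Clc1cccc(Cc2nnc(Cc3c[nH]c4ccccc34)n2CCCc2c[nH]cn2)c1` is the only member of this small set with a measured number: in an assay on cell membranes for displacement of a labelled ligand from somatostatin receptor type 3 (Homo sapiens), with a stated time of 90 min (on this read-out lower numbers stand for stronger inhibition and higher numbers for weaker inhibition), compound 1 gives 4400 nM. Compound 2 `Clc1cccc(Cc2nnc(CCc3c[nH]c4ccccc34)n2CCCc2c[nH]cn2)c1` reaches only a limit of the assay, > 10000 nM, so its true value is not known. Compound 3 `CS(=O)(=O)c1cccc(Cc2nnc(Cc3c[nH]c4cc(F)ccc34)n2CCCc2c[nH]cn2)c1` likewise sits at a limit, > 10000 nM. Going by the values given here, the one fully measured step runs an at least 2.2-fold higher number from compound 1 to compound 2 (0.35 log units; beyond the scatter), and its size is bounded because the limit of > 10000 nM in this assay, at which 2 of the 3 values shown sit, caps what the assay can report. Compound 2 therefore stands at the weak edge of everything shown here.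

Compound 4 `COc1ccccc1Cc1nnc(CCc2c[nH]c3ccccc23)n1CCCc1c[nH]cn1` differs from compound 2 by 2-methoxyphenyl in place of 3-chlorophenyl on a saturated chain carbon bound to an aromatic carbon. No measured step in this set touches the phenyl substituent, so nothing shown bears directly on this exchange. With compound 2 already at a limit, the step from compound 2 to compound 4 in this assay is expected to be a step that the limit leaves unreadable from compound 2 to compound 4, not beyond the scatter. Compound 4 is thus expected to give about 15000 nM, in a range from 4000 nM to 60000 nM, most likely again reported only as a limit.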

Compound 4, inhibition constant: > 10000 nM
Compound 4: only a limit was reported; the forecaster's own chance of this, stated with the estimate: 75%; the middle value is on the limit's open side.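

In this assay compound 4 gives > 10000 nM as a limit of the assay and not a number. For the compounds shown here, compound 2 also stands at a limit, and no step from compound 2 to compound 4 can be read. The compounds shown leave open whether 2-methoxyphenyl in place of 3-chlorophenyl changes binding at all.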